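Will a larger group change how well the cells tolerate compound 3?

The source may report more compounds than this note shows. Statements on the series, on what has been measured and on what is new or still open speak of the compounds shown alone.

In a functional assay on Vero cells (Chlorocebus sabaeus) for cytotoxicity (a higher number here means that more compound is tolerated, a lower number that less compound is tolerated), compound 1 (`O=c1ccn(CC2(CO)CC2CO)c(=O)[nH]1`) gives > 500 ug/mL, which is a limit of the assay and not a number. Compound 2 (`Cc1cn(CC2(CO)CC2CO)c(=O)[nH]c1=O`) gives > 500 ug/mL, and this too is only a limit. So compound 2 has no exact value, and the only comparison available is a step that the two limits leave unreadable from compound 1 to compound 2, where methyl replaces hydrogen on an aromatic carbon. The evidence so far is the limit of > 500 ug/mL in this assay, at which 2 of the 2 values shown sit.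

Compound 3 (`O=c1[nH]c(=O)n(CC2(CO)CC2CO)cc1/C=C/Cl`) carries 2-chloroethenyl in place of methyl on the same aromatic carbon: 2-chloroethenyl in place of methyl on an aromatic carbon. Going by the values given here, the one measured step has no readable size, so it offers only weak guidance. In this assay, no change beyond the scatter is expected, although a fall cannot be ruled out. The expected step is a number no higher from compound 2 to compound 3 (the limit leaves the size open). Compound 3 is estimated at 500 ug/mL, with an expected range of 200 ug/mL to 1000 ug/mL.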

Compound 3, half-maximal cytotoxic concentration: > 500 ug/mL
Compound 3 gave a limit, no number; the forecaster's own chance of this, stated with the estimate: 65%; the middle value lies on the limit itself.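

Going by these compounds alone, compound 1, compound 2 and compound 3 all end at a limit of the assay, not a number, so no step between them can be read. The compounds shown leave open how much of each is tolerated in this assay, and whether hydrogen, methyl or 2-chloroethenyl makes any difference there.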